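Notes on the step from compound 2 to compound 3

The compounds below may be only part of what the source reports. "The series", "measured", "known", "first", "only" and "open" are said of these compounds alone.

Compound 1 `O=c1cc(Cn2cc(CCO)nn2)c2ccc(O)cc2o1`: in a functional assay on CFPAC-1 cells (Homo sapiens) for inhibition, read by MTT assay, with a stated time of 72 h (on this read-out lower numbers stand for stronger inhibition and higher numbers for weaker inhibition), compound 1 gives > 100000 nM, which is a limit of the assay (the limit of > 100000 nM in this assay, at which 1 of the 2 values shown sits).
Compound 2 `CCCCCCCCc1cn(Cc2cc(=O)oc3cc(O)ccc23)nn1`: in this assay compound 2 gives 62700 nM.

Compound 2 holds the only number shown; the other value is a limit. Among the compounds with values here, the single measured step, an at least 1.5-fold lower number from compound 1 to compound 2 (0.20 log units; that floor lies within the scatter), starts from a limit and its floor lies within the scatter. Compound 3 `O=c1cc(Cn2cc(-c3cc(F)cc(F)c3)nn2)c2ccc(O)cc2o1` differs from compound 2 by 3,5-difluorophenyl in place of octyl on an aromatic carbon. Within the data shown here, no measured step covers this change, so nothing here points beyond the scatter in either direction. The estimate for compound 3 is 50000 nM, with a range of 12000 nM to 200000 nM. That estimate means an expected step of a 1.3-fold lower number from compound 2 to compound 3 (0.10 log units; within the scatter).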

Compound 3, half-maximal inhibitory concentration: > 100000 nM
Compound 3: only a limit was reported (the forecaster's own chance of this, stated with the estimate: 40%); middle value at least 2.0-fold (0.30 log units) from the limit.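

At this aromatic carbon, 3,5-difluorophenyl in place of octyl gives an at least 1.5-fold higher number from compound 2 to compound 3 (0.20 log units; that floor lies within the scatter) in this assay and so offers no lower number with an aromatic ring in this place. Compound 3 gives only a limit of the assay. Within the data shown here, the step from compound 1 to compound 3 joins two limits and cannot be read, and compound 2 remains the only compound with a number: the limit of > 100000 nM in this assay, at which 2 of the 3 values shown sit.

Going by these compounds, whether a chain longer than octyl would give a clearly lower number than compound 2 stays open. So does the outcome with an amine at this carbon.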